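The source may report more compounds than this note shows. Statements on the series, on what has been measured and on what is new or still open speak of the compounds shown alone.

Measured so far:
- compound 1 `CS(=O)(=O)c1cccc(S(=O)(=O)N(C2CC2)C2CCN(C(=O)c3cc(F)ccc3S(C)(=O)=O)CC2)c1` — 0%
- compound 2 `CS(=O)(=O)c1ccc(C(=O)N2CCC(N(C3CC3)S(=O)(=O)c3cccc(C(F)(F)F)c3)CC2)cc1` — 52%

In an assay on HEK293 cells for inhibition of Voltage-dependent N-type calcium channel subunit alpha-1B (Homo sapiens), read by FLIPR and calcium flux, tested at 1 uM (on this read-out higher numbers stand for more inhibition at the one concentration tested (going by the name of the read-out) and lower numbers for less inhibition), compound 1 gives 0%, the lowest of the two numbers; compound 2 gives 52%, beyond the scatter above it. Compound 3 `CS(=O)(=O)c1ccc(F)cc1C(=O)N1CCC(N(C2CC2)S(=O)(=O)c2ccc(C(F)(F)F)cc2)CC1` is not yet measured. From compound 1 it differs as follows: 4-(trifluoromethyl)phenyl in place of 3-(methylsulfonyl)phenyl on a sulfonyl sulfur. Compound 2 carries a trifluoromethylphenyl on its sulfonyl sulfur, and its value 52% is the only indication of what that group does here, so for compound 3 an upward step a number 35 percentage points higher from compound 1 to compound 3 (beyond the scatter) from compound 1 is expected, beyond the scatter but uncertain in size. Compound 3 is estimated at 35%, range 5% to 70%.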

Compound 3, a percentage reported as inhibition, at one concentration (the size of the read-out at that concentration, not a potency): 1%
Estimate against measurement, compound 3: 34 percentage points above; the whole stated range lies above it.
By their numbers in this assay, from the lowest: compounds 1 and 3 (each within the scatter of the next); then compound 2.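

In this assay the exchange on the sulfonyl sulfur gives a number 1 percentage points higher from compound 1 to compound 3 (within the scatter), so on the core of compound 1 the 4-(trifluoromethyl)phenyl and 3-(methylsulfonyl)phenyl groups cannot be told apart, and a trifluoromethyl group on this ring is not enough to raise the read-out. Compound 2 differs from compound 3 in more than one place, so this pair does not explain its value. Nothing at hand bears on the reason for this result.

Still open, as far as these compounds go, is whether a nitrile or an amine on this phenyl ring would move the read-out on the same core. Also open, from the compounds shown here alone, is which difference in the benzoyl part separates compound 2 from the others.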